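A few compounds are considered here, and "the series" means these few. Any claim that something is new, unique, unknown or untested is made for them only; others in the source may bear on it.

Measured in an assay on RBL-1 cells for inhibition of Polyunsaturated fatty acid 5-lipoxygenase (Rattus norvegicus); a lower number here means a stronger inhibitor, a higher number a weaker inhibitor:
compound 1 `CN(O)/C=C\C(=O)c1ccc([N+](=O)[O-])cc1`: 1500 nM
compound 2 `O=C(/C=C\N(O)Cc1ccccc1)c1ccc([N+](=O)[O-])cc1`: 2500 nM
compound 3 `CC(=O)ON(C)/C=C\C(=O)c1ccc(OCc2ccccc2)cc1`: > 25000 nM, which is a limit of the assay and not a number.

Compound 1 gives the lowest of the two numbers in this assay; compound 2 is its nearest neighbour, and the step of a 1.7-fold higher number from compound 1 to compound 2 (0.22 log units; within the scatter) lies within the scatter, so no order between the two is claimed. Compound 3 stands at the limit of > 25000 nM in this assay, at which 1 of the 3 values shown sits.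

Compound 4 `CN(O)/C=C\C(=O)c1ccc(F)cc1` differs from compound 1 by fluoro in place of nitro on an aromatic carbon. Going by the values given here, no measured step changes this position; the one measured step, a 1.7-fold higher number from compound 1 to compound 2 (0.22 log units; within the scatter), concerns the substituent on the nitrogen only and stayed within the scatter, so it gives no guidance on the size or direction here. For compound 4 a modest weakening is expected, a 2.3-fold higher number from compound 1 to compound 4 (0.37 log units; beyond the scatter), with wide uncertainty. Compound 4 is estimated at 3500 nM in this assay, within 900 nM to 14000 nM.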

Compound 4, half-maximal inhibitory concentration: 5000 nM
For compound 4 the middle estimate is 1.4-fold (0.15 log units) below the measured one; low and high end bracket the measured number.
By their numbers in this assay, from the lowest: compounds 1, 2 and 4 (each within the scatter of the next, the first and the last beyond it). At a limit, above all of these: compound 3.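

Fluoro in place of nitro on the aromatic carbon para to the group of 7 heavy atoms gives a 3.3-fold higher number from compound 1 to compound 4 (0.52 log units; beyond the scatter), so in this assay this position shows a step beyond the scatter, unlike the change on the nitrogen, a 1.7-fold higher number from compound 1 to compound 2 (0.22 log units; within the scatter). Compound 4 still gives a measured number, so nitro is not required for a measured value in this series. Nothing shown accounts for the size of this step.

Open, on these data alone, is how an amine, a carboxylic acid or a methoxy group on this carbon would compare with nitro and fluoro. Also open, as far as these compounds go, is whether the same change behaves alike with the benzyl group on the nitrogen of compound 2.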